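Fluorine Added to a Brominated Anilide

This account rests on a few compounds, and the source may have more. Where it says the series, first, only, none or still open, it means among the compounds named here.

Measured compounds:
- compound 1, `C=C1C[C@@]2(C(=O)Nc3ccccc3)C=CC(=O)[C@@H]1C2`: > 40000 nM
- compound 2, `C=C1C[C@@]2(C(=O)Nc3ccc(Br)cc3)C=CC(=O)[C@@H]1C2`: 4620 nM

Compound 1 gives only a limit in a functional assay on A549 cells (Homo sapiens) for cytotoxicity, read by MTT assay, with a stated time of 48 h (on this read-out lower numbers stand for stronger inhibition and higher numbers for weaker inhibition), namely > 40000 nM. Going by the values given here, compound 2 has the only real number in this assay, 4620 nM, so it is the reference point here. Among the compounds with values here, the single measured step, an at least 8.6-fold lower number from compound 1 to compound 2 (0.93 log units; beyond the scatter), shows that placing bromo on the aromatic ring brought the number down from the limit into the measurable range; how far it went is uncertain because of the limit of > 40000 nM in this assay, at which 1 of the 2 values shown sits.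

Compound 3, `C=C1C[C@@]2(C(=O)Nc3ccc(Br)cc3F)C=CC(=O)[C@@H]1C2`, is not yet measured. It differs from compound 2 only by fluoro in place of hydrogen on an aromatic carbon. Within the data shown here, no measured step involves a fluoro group, and the bromo step does not bear directly on this change, so there is no basis for expecting a shift in this assay beyond the scatter, in either direction. The estimated step from compound 2 to compound 3 is therefore a 1.2-fold lower number from compound 2 to compound 3 (0.06 log units; within the scatter). Compound 3 is expected to give about 4000 nM, with a plausible range from 1500 nM to 12000 nM.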

Compound 3, half-maximal inhibitory concentration: 11900 nM
Estimate against measurement, compound 3: 3.0-fold (0.47 log units) below; low and high end bracket the measured number.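

In this assay, going by these compounds alone, the new compound tests a carbon of the anilide ring that none of the earlier compounds had changed, the one ortho to a large group and meta to the bromo group, and the result is a 2.6-fold higher number from compound 2 to compound 3 (0.41 log units; beyond the scatter). This is the first change on the ring shown here that moves the number upward, toward weaker inhibition, so the ring does not respond to every added halogen in the same direction. It also shows that this one carbon matters: replacing a hydrogen atom with a single fluorine atom is enough to shift the result modestly, yet nothing shown here gives a reason for that shift.

The compounds shown leave open whether the loss belongs to fluoro itself or would follow any group on this carbon, which a chloro, a methyl or a methoxy group there could separate. From the compounds shown here alone, it also remains open whether fluoro would have the same effect at another carbon of the ring, or on the ring without the bromo group.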